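The compounds below may be only part of what the source reports. "The series", "measured", "known", "first", "only" and "open" are said of these compounds alone.

Measured so far in an ADME assay on the whole organism (Mus musculus, strain C57BL6/N) for metabolic stability, read by LC-MS, with a stated time of 24 h, at a dose of 10 mg/kg by the oral route; on this read-out higher numbers stand for a longer-lived compound and lower numbers for a shorter-lived compound:
- compound 1 `CNc1cc(C)c(C(N)=O)cn1`: 1.11 h
- compound 2 `NC(=O)c1cnc2c(c1)CCN2`: 0.39 h

Compound 2 holds the lower of the two numbers at 0.39 h, and its gap to compound 1 lies beyond the usual scatter.

The next compound, not yet measured, is compound 3 `Cc1c(C(N)=O)cnc2c1CCN2`. It is compound 2 with methyl in place of hydrogen on an aromatic carbon, ortho to a carbamoyl group and opposite the ring nitrogen.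

Among the compounds with values here, no measured pair isolates this change, so the expectation rests on thin evidence. Compound 1 also carries a methyl ortho to a carbamoyl group, but it differs from compound 2 in more than that one place, so the value of compound 1 at 1.11 h is only a weak guide. In this assay a modest rise is expected, about the size of the usual scatter and possibly no real change at all. The expected step is a 1.8-fold higher number from compound 2 to compound 3 (0.25 log units; within the scatter). The estimate for compound 3 is 0.7 h, with an expected range of 0.35 h to 1.4 h.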

Compound 3, half-life: 0.37 h
Compound 3: middle estimate off by 1.9-fold (0.28 log units), on the high side; the range from low to high includes it.
By their numbers in this assay, from the lowest: compounds 3 and 2 (each within the scatter of the next); then compound 1.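

In this assay, within the data shown here, this is the first pair to isolate methyl in place of hydrogen on an aromatic carbon, and it gives a 1.1-fold lower number from compound 2 to compound 3 (0.02 log units; within the scatter) with the step inside the usual scatter. At this position, ortho to a carbamoyl group and opposite the ring nitrogen, the methyl therefore leaves the half-life without a real change on the shared core of compound 2 and compound 3, and the pair offers no sign that the hydrogen at this place limits the half-life. No supporting measurement is available to explain this result.

Going by these compounds, a single small group at one position is all that this pair covers, so it remains open whether chlorine, ethyl or methoxy at the same place would also leave the half-life unchanged. On these data alone, it is also open whether changes elsewhere on the core, such as a substituent on the ring amine or a replacement of the carbamoyl group by a nitrile, would shift the half-life where this methyl did not.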